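Swapping the aryl group: from chloro to methoxy on the side chain

The source may hold more compounds than are shown below. What is called first, only, known or untested is meant among the compounds shown, and "the series" means these compounds.

Compound 1, `OC(CCn1nc2c(Br)c(Br)c(Br)c(Br)c2n1)c1ccc(Br)cc1`, in a functional assay on MCF7 cells (Homo sapiens) for antiproliferative activity, read by MTT assay, with a stated time of 48 h, tested at 50 uM (on this read-out higher numbers stand for a weaker effect at the one concentration tested and lower numbers for a stronger effect), gives 15%.
Compound 2, `OC(CCn1nc2c(Br)c(Br)c(Br)c(Br)c2n1)c1cccc(Cl)c1`, gives 12%.
Compound 3, `OC(CCn1nc2c(Br)c(Br)c(Br)c(Br)c2n1)c1ccc(Cl)cc1`, gives 9%.

All three share the same core and differ only in the aryl group on the saturated chain carbon bound to an oxygen. Compound 3 has the lowest of the three numbers, but its nearest neighbour is compound 2 with a number 3 percentage points lower from compound 2 to compound 3 (within the scatter) and its furthest is compound 1 with a number 6 percentage points lower from compound 1 to compound 3 (within the scatter), both within the scatter, so no real order among the three can be claimed.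

Compound 4, `COc1cccc(C(O)CCn2nc3c(Br)c(Br)c(Br)c(Br)c3n2)c1`, is not yet measured. It differs from compound 3 by 3-methoxyphenyl in place of 4-chlorophenyl on a saturated chain carbon bound to an oxygen on a saturated carbon and a saturated chain carbon. Going by the values given here, the steps that bear on this are the other aryl swaps, a number 3 percentage points lower from compound 1 to compound 2 (within the scatter) and a number 3 percentage points lower from compound 2 to compound 3 (within the scatter), which were both within the scatter. A methoxy group appears nowhere among the measured compounds, so nothing shows how it behaves here. The expectation in this assay is therefore a step of a number 5 percentage points higher from compound 3 to compound 4 (within the scatter), no larger than the scatter, with extra uncertainty for the untested group. Compound 4 is estimated at 14%, in a range from 4% to 32%.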

Compound 4, a percentage reported as activity, at one concentration (the size of the read-out at that concentration, not a potency): 20%
Compound 4: middle estimate off by 6 percentage points, on the low side; low and high end bracket the measured number.
By their numbers in this assay, from the lowest: compounds 3, 2, 1 and 4 (each within the scatter of the next, the first and the last beyond it).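

In this assay, going by these compounds alone, 3-methoxyphenyl in place of 4-chlorophenyl gives a number 11 percentage points higher from compound 3 to compound 4 (beyond the scatter), the first aryl swap at this saturated chain carbon to clear the scatter, and it points towards a weaker effect. The separation holds against compound 3 alone: a number 8 percentage points higher from compound 2 to compound 4 (within the scatter) and a number 5 percentage points higher from compound 1 to compound 4 (within the scatter) both stay within the scatter, so the methoxy compound does not stand apart from all the halogen compounds. No measurement here offers a reason for this step.

The step from compound 3 also changes both the substituent and its printed ring number, so a 4-methoxyphenyl group would be needed to tell those two changes apart. As far as these compounds go, how an amine or a carboxylic acid on this aryl ring, or a longer chain to the core, would read in this assay remains open.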